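Swapping the five-membered ring partner on a shared core

The source may hold more compounds than are shown below. What is called first, only, known or untested is meant among the compounds shown, and "the series" means these compounds.

Measured compounds in an in vitro functional assay on cells (Fibroblast) for agonist activity at Alpha-1D adrenergic receptor (Homo sapiens); on this read-out higher numbers stand for an effect only at larger amounts of compound and lower numbers for an effect already at smaller amounts:
- Compound 1 `CCn1cc(-c2ccccc2NCC2=NCCN2)cn1` gives < 100000 nM, which is a limit of the assay and not a number.
- Compound 2 `Cc1n[nH]c(-c2ccccc2NCC2=NCCN2)n1` gives < 5020 nM, again a limit and not a number.
- Compound 3 `Cn1cc(-c2ccccc2NCC2=NCCN2)cn1` gives < 100000 nM, also a limit and not a number.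

Compound 3 therefore stands at a limit, and so do the other two values; none of the three is a measured number. The step that the two limits leave unreadable from compound 1 to compound 3 and the step that the two limits leave unreadable from compound 2 to compound 3 both bear on the move to compound 4, but the two limits leave each of them unreadable, so neither tells how large a change of this kind can be.

Compound 4 `Cn1ccnc1-c1ccccc1NCC1=NCCN1` carries the change (1-methyl-1H-imidazol-2-yl in place of 1-methyl-1H-pyrazol-4-yl on an aromatic carbon). Because the limit of < 100000 nM in this assay, at which 2 of the 3 values shown sit, and the limit of < 5020 nM in this assay, at which 1 of the 3 values shown sits, are all the evidence there is, no direction and no size of step can be read from the measured compounds. The step that the limit leaves unreadable from compound 3 to compound 4 is an estimate only. Compound 4 is expected at 5000 nM, within 300 nM to 80000 nM.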

Compound 4, half-maximal effective concentration: 200 nM
Estimate against measurement, compound 4: 25-fold (1.40 log units) above; measured number below the stated range.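

Compound 2 and compound 3 each stand only at a limit of the assay, not a number, so neither step to compound 4 can be read. As far as these compounds go, how much swapping in 1-methyl-1H-imidazol-2-yl changes the result in this assay stays open.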